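Removing a Methoxy Group on a Shared Core

The source may report more compounds than this note shows. Statements on the series, on what has been measured and on what is new or still open speak of the compounds shown alone.

Of the compounds shown here, three have been measured here and one has not. Compound 1 `NCCNc1cc2c(cc1F)c(=O)c(C(=O)O)cn2Cc1ccc(-c2ccccc2)cc1`, compound 2 `COc1c(NCCN)c(F)cc2c(=O)c(C(=O)O)cn(Cc3ccc(-c4ccccc4)cc3)c12` and compound 3 `CNCCCCNc1c(F)cc2c(=O)c(C(=O)O)cn(Cc3ccc(-c4ccccc4)cc3)c2c1OC` were tested in an assay on isolated protein for inhibition of DNA topoisomerase 1 (Homo sapiens), with a stated time of 15 min; a lower number here means a stronger inhibitor, a higher number a weaker inhibitor; compound 4 `CNCCCCNc1cc2c(cc1F)c(=O)c(C(=O)O)cn2Cc1ccc(-c2ccccc2)cc1` awaits testing. In this assay compound 1 gives 72800 nM. For compound 2 the assay reports only a limit, > 200000 nM. For compound 3 the assay likewise reports only a limit, > 200000 nM. As far as these compounds go, two of the three measured values therefore sit at the limit of > 200000 nM in this assay, at which 2 of the 3 values shown sit, so their true numbers are unknown.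

Compound 3 differs from compound 2 by 2-(methylamino)ethyl in place of amino on a saturated chain carbon, two bonds along the chain from a nitrogen on an aromatic ring, and the step between them is a step that the two limits leave unreadable from compound 2 to compound 3.

Compound 1 arises from compound 2 by hydrogen in place of methoxy on an aromatic carbon, which gave an at least 2.7-fold lower number from compound 2 to compound 1 (0.43 log units; beyond the scatter). Compound 4 arises from compound 3 by hydrogen in place of methoxy on an aromatic carbon. This is the same kind of change, but not the same one: in compound 2 the place is ortho to a (2-aminoethyl)amino group (4 heavy atoms), while in compound 3 it is ortho to a (4-(methylamino)butyl)amino group (7 heavy atoms).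

Compound 4 is expected to reach about 80000 nM in this assay. The estimated range for compound 4 runs from 25000 nM to 200000 nM, and the assay may again report only a limit. The expected step is an at least 2.5-fold lower number from compound 3 to compound 4 (0.39 log units; beyond the scatter), resting on an at least 2.7-fold lower number from compound 2 to compound 1 (0.43 log units; beyond the scatter) and on compound 1 at 72800 nM.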

Compound 4, half-maximal inhibitory concentration: 88300 nM
For compound 4 the middle estimate is 1.1-fold (0.04 log units) below the measured one; low and high end bracket the measured number.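

In this assay, hydrogen in place of methoxy on an aromatic carbon gives an at least 2.2-fold lower number from compound 3 to compound 4 (0.35 log units; beyond the scatter). The change thus lowers the number on both cores, whichever of the two amine chains is present, but the two sizes cannot be told apart: the same change on two cores in this assay, an at least 2.7-fold lower number (0.43 log units; beyond the scatter) from compound 2 to compound 1 and an at least 2.2-fold lower number (0.35 log units; beyond the scatter) from compound 3 to compound 4; the limit leaves it open whether they differ. As far as these compounds go, the true size of each step stays unknown, and two examples make no rule for other chains, since each step starts from a compound reported only as a limit: the limit of > 200000 nM in this assay, at which 2 of the 4 values shown sit.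

Without the methoxy group, 2-(methylamino)ethyl in place of amino on a saturated chain carbon gives a 1.2-fold higher number from compound 1 to compound 4 (0.08 log units; within the scatter), so the longer chain makes no difference beyond the scatter there, while the matching step with the methoxy group in place cannot be read from its two limits. The compounds shown leave open whether a hydroxyl or an ethoxy group in place of the methoxy would raise the number as the methoxy does, and whether a still longer chain or a tertiary amine at the chain's end would shift the number on either core.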